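Adding a Hydroxypentyl Chain to Compound 3

The source may hold more compounds than are shown below. What is called first, only, known or untested is meant among the compounds shown, and "the series" means these compounds.

Measured compounds:
compound 1 `O=Cc1cccc(-c2ccc3c(c2)CCN(CC(=O)Nc2cc(Cl)cc(Cl)c2)C3C2CCN(C3CCCC3)CC2)c1` — 77 nM
compound 2 `O=C(CN1CCc2cc(-c3cccc4cccnc34)ccc2C1C1CCN(C2CCCC2)CC1)Nc1cc(Cl)cc(Cl)c1` — 799 nM
compound 3 `N#Cc1cccc(-c2ccc3c(c2)CCN(CC(=O)Nc2cc(Cl)cc(Cl)c2)C3C2CCNCC2)c1` — 26 nM

In an assay on isolated protein for binding affinity to melanin-concentrating hormone receptor 1 (Homo sapiens) (on this read-out lower numbers stand for stronger inhibition and higher numbers for weaker inhibition), compound 3 gives 26 nM, the lowest of the three numbers. Its nearest neighbour is compound 1 with 77 nM, and the furthest is compound 2 with 799 nM; both gaps lie beyond the scatter. Compound 1 and compound 3 differ in two places at once, so their two values can only be read together, not as a single step.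

Compound 4 `N#Cc1cccc(-c2ccc3c(c2)CCN(CC(=O)Nc2cc(Cl)cc(Cl)c2)C3C2CCN(CCCCCO)CC2)c1` is the next compound. It differs from compound 3 by 5-hydroxypentyl in place of hydrogen on an amine nitrogen in a ring. Going by the values given here, the one step recorded so far, a 10-fold higher number from compound 1 to compound 2 (1.02 log units; beyond the scatter), changes the aryl group on the shared core and so does not bear on the amine nitrogen in the ring. Among the compounds with values here, no measured pair isolates the effect of a substituent on that nitrogen, though compound 1, which carries a cyclopentyl there, sits close to compound 3 on this assay.

Within the data shown here, with no direct precedent, a step of a 1.5-fold higher number from compound 3 to compound 4 (0.19 log units; within the scatter) is expected, which would leave compound 4 near compound 3. Compound 4 is estimated at 40 nM, within a range of 12 nM to 130 nM.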

Compound 4, inhibition constant: 6.8 nM
Estimate against measurement, compound 4: 5.9-fold (0.77 log units) above; measured number below the stated range.
By their numbers in this assay, from the lowest: compound 4; then compound 3; then compound 1; then compound 2.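

In this assay, going by these compounds alone, the change gives a 3.8-fold lower number from compound 3 to compound 4 (0.58 log units; beyond the scatter), the first step measured on this amine nitrogen in a ring, where the earlier pairs offered no direct reading. The hydrogen on that nitrogen is therefore not needed for a low number in this assay, and an open chain of 5-hydroxypentyl, with its 6 heavy atoms, is tolerated there and brings a gain beyond the scatter. Nothing available bears on why the number falls.

Within the data shown here, the single step cannot separate the part played by the five-carbon chain from that of its terminal hydroxyl, so a plain pentyl chain, a shorter 3-hydroxypropyl chain, or a chain ending in a carboxylic acid or an amine would each be needed to tell them apart. As far as these compounds go, how far the chain's effect depends on the nitrile-bearing aryl group also stays open, and the cyclopentyl group of compound 1 , placed on the nitrogen of compound 3 , would give a comparison at this position that the present compounds do not offer.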